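Swapping the Diethylamino Group of Compound 2

The source may report more compounds than this note shows. Statements on the series, on what has been measured and on what is new or still open speak of the compounds shown alone.

Three analogues sharing one core have been tested in a functional assay on A549 cells (Homo sapiens) for antiproliferative activity, read by MTT assay, with a stated time of 48 h; a lower number here means a stronger inhibitor, a higher number a weaker inhibitor. Compound 2 `CCN(CC)C/C1=C/C[C@](C)(CCC=C(C)C)/C=C/[C@@H](OC(=O)C=C(C)C)[C@](C)(O)/C=C/C1=O` gives 130 nM, the lowest of the two numbers shown; compound 1 `COC/C1=C/C[C@](C)(CCC=C(C)C)/C=C/[C@@H](OC(=O)C=C(C)C)[C@](C)(OC)/C=C/C1=O`, which differs from it in several places, gives 4180 nM, a gap beyond the scatter. Compound 3 `CC(C)=CCC[C@]1(C)/C=C/[C@@H](OC(=O)C=C(C)C)[C@](C)(O)CCC(=O)/C(CO)=C\C1` reaches only a limit of the assay, > 40000 nM. Compound 4 `CSC(=S)OC/C1=C/C[C@](C)(CCC=C(C)C)/C=C/[C@@H](OC(=O)C=C(C)C)[C@](C)(O)/C=C/C1=O` has not yet been measured; relative to compound 2 it carries a group of 5 heavy atoms (2 carbon, 1 oxygen, 2 sulfur; no ring) in place of a group of 5 heavy atoms (4 carbon, 1 nitrogen; no ring), on a saturated chain carbon bound to a double-bonded ring carbon. For the measured compounds named here, no measured pair isolates this exact change, so the direction rests on expectation alone: a loss of potency is expected, and the step from compound 2 to compound 4 is estimated as a 12-fold higher number from compound 2 to compound 4 (1.06 log units; beyond the scatter). Compound 4 is therefore expected to give about 1500 nM, between 300 nM and 8000 nM.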

Compound 4, half-maximal inhibitory concentration: 380 nM
Estimate against measurement, compound 4: 3.9-fold (0.60 log units) above, within the range that was stated.
By their numbers in this assay, from the lowest: compound 2; then compound 4; then compound 1. At a limit, above all of these: compound 3.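

In this assay, for the compounds shown here, replacing the diethylamino group on this saturated chain carbon, the first change here seen on its own, gives a 2.9-fold higher number from compound 2 to compound 4 (0.47 log units; beyond the scatter) as a modest loss. A group without nitrogen therefore keeps much of the potency of compound 2, so an amine is not required at this place. Nothing measured here accounts for the size of this step. Going by these compounds, whether a smaller amine such as dimethylamino, or a ring amine such as morpholine, would match compound 2 remains open. So does the outcome for a simple acetate ester at this place.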